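Changing the Aromatic Group on the Ring Nitrogen

The source may report more compounds than this note shows. Statements on the series, on what has been measured and on what is new or still open speak of the compounds shown alone.

All four compounds share one core and differ only in the aromatic group attached to a five-membered aromatic ring with 3 nitrogen. They were examined in a functional assay on PC-3 cells (Homo sapiens) for cytotoxicity, read by MTT assay, with a stated time of 24 h; on this read-out higher numbers stand for weaker inhibition and lower numbers for stronger inhibition. Going by the values given here, compound 1 `COc1ccc(/C=C\C(=O)O)c(OCc2cn(-c3cccc([N+](=O)[O-])c3)nn2)c1CC=C(C)C` is the only one with a number: in this assay compound 1 gives 42100 nM, a weak effect. Compound 2 `COc1ccc(/C=C\C(=O)O)c(OCc2cn(-c3cccnc3Cl)nn2)c1CC=C(C)C` has no reported result in this assay: for compound 2 the entry reads "not determined" (no result reported). Compound 3 `COc1ccc(/C=C\C(=O)O)c(OCc2cn(-c3nc4ccccc4s3)nn2)c1CC=C(C)C` carries a 1,3-benzothiazol-2-yl group, and for it too no number was reported in this assay, where compound 3 is recorded as "not determined" (no result reported), so compound 3 stands without a value, alongside one further compound in the same position. Compound 4 `COc1ccc(/C=C\C(=O)O)c(OCc2cn(-c3ccccc3F)nn2)c1CC=C(C)C` is the compound still to be measured. The change from compound 3 to compound 4 is 2-fluorophenyl in place of 1,3-benzothiazol-2-yl on an aromatic nitrogen. Among the compounds with values here, with no measured step anywhere, the only anchor is compound 1, whose 42100 nM shows how weak this class of compounds is in this assay. The change from compound 3 to compound 4 is not expected to move the number beyond the usual scatter in either direction, and the result should land near that anchor. Compound 4 is expected to give about 40000 nM in this assay, within an estimated range from 12000 nM to 130000 nM.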

Compound 4, half-maximal inhibitory concentration: 24200 nM
Beside the measured number, compound 4's estimate is 1.7-fold (0.22 log units) above it, within the range that was stated.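

Going by these compounds alone, compound 4 supplies the first step that can be read at the aromatic group on the ring nitrogen. In this assay replacing 3-nitrophenyl with 2-fluorophenyl gives a 1.7-fold lower number from compound 1 to compound 4 (0.24 log units; within the scatter) and so the two compounds cannot be told apart, which shows that this one swap leaves the result in the same weak range and that a second aromatic group on this nitrogen can share the level of the first. The step from compound 3 to compound 4 and any step involving compound 2 cannot be read, since neither compound 2 nor compound 3 has a number, and nothing in the data explains the closeness of the two measured compounds.

The compounds shown leave open how a plain alkyl chain or an amine-bearing phenyl group would fare on this nitrogen in place of the groups seen here. They also leave open whether a methyl ester in place of the carboxylic acid of the shared core would lift the series out of this weak range.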